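This account rests on a few compounds, and the source may have more. Where it says the series, first, only, none or still open, it means among the compounds named here.

In a functional assay on RD cells (Homo sapiens) for inhibition, read by luminescence and ATP content, with a stated time of 72 h (a higher number here means that more compound is tolerated, a lower number that less compound is tolerated), compound 1 `CCOC(=O)c1cnc2ccc(-c3ccc(N)cc3)cc2c1` reads only as a limit, > 7400 nM. Compound 2 `CCCc1nc(-c2cnc3ccc(-c4ccc(N)cc4)cc3c2)no1` also reads only as a limit, > 800 nM. For the measured compounds named here, the one measured step, a step that the two limits leave unreadable from compound 1 to compound 2, therefore gives no size to work from. Compound 3 `CC(C)c1nc(-c2cnc3ccc(-c4ccc(N)cc4)cc3c2)no1` carries isopropyl in place of propyl on an aromatic carbon, (isopropyl in place of propyl on an aromatic carbon). With no readable step behind it, no shift beyond the scatter is expected, and the estimated step is a step that the limit leaves unreadable from compound 2 to compound 3. In this assay, compound 3 is expected at 1500 nM, with an estimated range of 800 nM to 6000 nM.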

Compound 3, half-maximal cytotoxic concentration: > 800 nM
Compound 3 gave a limit, no number; the forecaster's own chance of this, stated with the estimate: 70%; the middle value is on the limit's open side.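

For the compounds shown here, compound 1, compound 2 and compound 3 all read only as limits in this assay, so no step among them can be read. The compounds shown leave open whether swapping propyl for isopropyl changes tolerated concentration at all.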